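The compounds below may be only part of what the source reports. "The series", "measured", "known", "first", "only" and "open" are said of these compounds alone.

Measured compounds:
compound 1 `COc1ccc(CNc2nc(N3CCN(C4CCCC4)CC3)c3ncn(CCCN4CCCC4)c3n2)cc1`, 240 nM
compound 2 `CCN1CCN(c2nc(NCc3ccc(OC)cc3)nc3c2ncn3CCCN2CCCC2)CC1`, 80 nM
compound 3 `CCN1CCN(c2nc(N)nc3c2ncn3CCCN2CCCC2)CC1`, 190 nM

All three were run in an assay on HEK293 cells for antagonist activity at Toll-like receptor 9 (Homo sapiens), read by spectrophotometry; a higher number here means a weaker inhibitor, a lower number a stronger inhibitor. Compound 2 gives 80 nM. Two single changes depart from it. The first, (cyclopentyl in place of ethyl on an amine nitrogen in a ring), brings a 3.0-fold higher number from compound 2 to compound 1 (0.48 log units; beyond the scatter), so compound 1 gives 240 nM. The second, (hydrogen in place of 4-methoxybenzyl on a nitrogen on an aromatic ring), brings a 2.4-fold higher number from compound 2 to compound 3 (0.38 log units; beyond the scatter), so compound 3 gives 190 nM. The values of compound 1 and compound 3 lie within the scatter of each other.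

Compound 4 `Nc1nc(N2CCN(C3CCCC3)CC2)c2ncn(CCCN3CCCC3)c2n1` is not yet measured. It differs from compound 3 by cyclopentyl in place of ethyl on an amine nitrogen in a ring, and this is the same change as that from compound 2 to compound 1, made at an identically described place; the two cores differ by hydrogen in place of 4-methoxybenzyl on a nitrogen on an aromatic ring. Within the data shown here, with one pair as the only precedent, a step of similar direction and size is expected: a 2.6-fold higher number from compound 3 to compound 4 (0.42 log units; beyond the scatter), resting on a 3.0-fold higher number from compound 2 to compound 1 (0.48 log units; beyond the scatter) and on compound 3 at 190 nM. Compound 4 is accordingly estimated at 500 nM in this assay, with a plausible range from 200 nM to 1300 nM.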

Compound 4, half-maximal inhibitory concentration: 120 nM
Compound 4: the middle estimate sits 4.2-fold (0.62 log units) above what was measured; the whole stated range lies above it.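

In this assay, cyclopentyl in place of ethyl gives a 1.6-fold lower number from compound 3 to compound 4 (0.20 log units; within the scatter) once the 4-methoxybenzyl is gone, so the step seen on the core of compound 2 does not carry over to the core of compound 3: the same change on two cores in this assay, a 3.0-fold higher number (0.48 log units; beyond the scatter) from compound 2 to compound 1 and a 1.6-fold lower number (0.20 log units; within the scatter) from compound 3 to compound 4, 4.8-fold (0.68 log units) apart, beyond the scatter of two such steps. Read the other way, hydrogen in place of 4-methoxybenzyl gives a 2.0-fold lower number from compound 1 to compound 4 (0.30 log units; within the scatter) when cyclopentyl is present, and this change also fails to carry over: the same change on two cores in this assay, a 2.4-fold higher number (0.38 log units; beyond the scatter) from compound 2 to compound 3 and a 2.0-fold lower number (0.30 log units; within the scatter) from compound 1 to compound 4, 4.8-fold (0.68 log units) apart, beyond the scatter of two such steps. These two gaps come from the same four compounds and so form one finding of non-additivity, not two; it shows that a step from one core is a poor guide on the other here, but not why, and not what the change would do on any further core.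

Open, from the compounds shown here alone, is whether a smaller or larger group on the amine nitrogen in a ring, such as methyl, isopropyl or cyclohexyl, follows the step on the core of compound 2 or that on the core of compound 3. Equally open, going by these compounds, is whether a plain benzyl in place of 4-methoxybenzyl shows the same dependence.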